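The source may hold more compounds than are shown below. What is called first, only, known or untested is meant among the compounds shown, and "the series" means these compounds.

Compounds measured so far:
Compound 1 `O=C1Nc2c(ccc(F)c2F)C1(c1ccccc1)c1ccc(O)cc1` – 8.9 nM
Compound 2 `COc1ccc(C2(c3cccc(O)c3)C(=O)Nc3c2ccc(F)c3F)cc1` – 145 nM

In a functional assay on PC-3 cells (Homo sapiens) for cytotoxicity, read by WST assay, with a stated time of 72 h (a higher number here means a weaker inhibitor, a lower number a stronger inhibitor), compound 1 gives 8.9 nM, the lowest of the two numbers. Compound 2 gives 145 nM, a higher value that lies beyond the scatter, though no single-point comparison links the two. Compound 3 `O=C1Nc2c(ccc(F)c2F)C1(c1ccc(O)cc1)c1cccs1` differs from compound 1 in one place: thiophen-2-yl in place of phenyl on a saturated ring carbon. For the measured compounds named here, no measured pair shows the effect of this change, so the expectation rests on compound 1 alone. The step of a 1.3-fold higher number from compound 1 to compound 3 (0.13 log units; within the scatter) is expected to be small, at most a slight weakening, within the scatter. For compound 3 the estimate is 12 nM, with a range from 4 nM to 40 nM.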

Compound 3, half-maximal inhibitory concentration: 0.3 nM
The estimate for compound 3 lay 40-fold (1.60 log units) above the measured number; the measured number lies below the stated range.
By their numbers in this assay, from the lowest: compound 3; then compound 1; then compound 2.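

Thiophen-2-yl in place of phenyl on this saturated ring carbon gives a 30-fold lower number from compound 1 to compound 3 (1.47 log units; beyond the scatter) in this assay and so shows that the number responds strongly to which aromatic ring sits at this position. This is the only one-place comparison shown, and it sets a five-membered aromatic ring with one hetero atom clearly ahead of the six-membered carbon ring on this core. No measurement at hand accounts for this step. On these data alone, whether furan-2-yl or thiophen-3-yl would behave like thiophen-2-yl stays open. So does the outcome of placing an amine or a carboxylic acid on the thiophene ring.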